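A few compounds are considered here, and "the series" means these few. Any claim that something is new, unique, unknown or untested is made for them only; others in the source may bear on it.

Measured in a functional assay on HeLa cells (Homo sapiens) for cytotoxicity, read by MTT assay, with a stated time of 24 h; on this read-out lower numbers stand for stronger inhibition and higher numbers for weaker inhibition:
- compound 1 `COc1cc(/C=C2\CN(C)C/C(=C\c3ccccc3F)C2=O)cc(OC)c1OC`: 3220 nM
- compound 2 `COc1cc(/C=C2\CN(C)C/C(=C\c3cc(OC)c(OC)c(OC)c3)C2=O)cc(OC)c1`: 2300 nM
- compound 3 `COc1cc(/C=C2\CN(C)C/C(=C\c3ccc(F)cc3)C2=O)cc(OC)c1OC`: 7250 nM

In this assay, compound 3 gives the highest number of the three, and both other compounds lie below it by steps beyond the scatter. Compound 4 `COc1cc(/C=C2\CN(C)C/C(=C\c3ccc(Cl)cc3)C2=O)cc(OC)c1OC` remains unmeasured. It departs from compound 3 as follows: chloro in place of fluoro on an aromatic carbon. In words, this is chloro in place of fluoro on an aromatic carbon, para to a large group, or 4-fluorophenyl to 4-chlorophenyl.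

Among the measured compounds shown here, no measured pair makes this exchange, so the evidence is indirect. The closest case is a 2.3-fold higher number from compound 1 to compound 3 (0.35 log units; beyond the scatter), where the fluoro group stays and the aryl group changes from 2-fluorophenyl to 4-fluorophenyl. Also relevant is a 3.2-fold higher number from compound 2 to compound 3 (0.50 log units; beyond the scatter), which replaces 3,5-dimethoxyphenyl with 4-fluorophenyl. Both steps are modest, while a 1.4-fold lower number from compound 1 to compound 2 (0.15 log units; within the scatter) stays within the scatter. The data show no direction for fluoro to chloro, so no step beyond the scatter is expected, with a slight lean towards a lower number, since compound 3 sits at the top of the range. The expected change is a 1.3-fold lower number from compound 3 to compound 4 (0.10 log units; within the scatter). Compound 4 is estimated at 5800 nM, with an expected range of 2500 nM to 13000 nM.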

Compound 4, half-maximal inhibitory concentration: > 20000 nM
Compound 4 gave a limit, no number; the forecaster's own chance of this, stated with the estimate: 3%; middle value at least 3.4-fold (0.53 log units) from the limit.
By their numbers in this assay, from the lowest: compounds 2 and 1 (each within the scatter of the next); then compound 3. At a limit, above all of these: compound 4.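

In this assay compound 4 gives a limit and not a number: the limit of > 20000 nM in this assay, at which 1 of the 4 values shown sits. Among the compounds shown here, this is the first direct reading of chloro in place of fluoro on an aromatic carbon, para to a large group, and the exchange of this single atom is not neutral here: the step is beyond the scatter (an at least 2.7-fold higher number from compound 3 to compound 4 (0.44 log units; beyond the scatter)). The earlier compounds shown here varied only the fluorophenyl and dimethoxyphenyl groups, whereas the 4-chlorophenyl group now extends the range seen at this aryl position, with the steps from the other two compounds also beyond the scatter (an at least 8.6-fold higher number from compound 2 to compound 4 (0.93 log units; beyond the scatter) and an at least 6.2-fold higher number from compound 1 to compound 4 (0.79 log units; beyond the scatter)).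

On these data alone, how far the value of compound 4 lies past its limit stays open, and with it the true size of all three steps. With only fluoro and chloro shown at this place, the compounds leave open how bromo, methyl, an amine or a carboxylic acid would read there, so no trend across substituents can be drawn from this one exchange.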